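The source may report more compounds than this note shows. Statements on the series, on what has been measured and on what is new or still open speak of the compounds shown alone.

In a functional assay on P388 cells (Mus musculus) for cytotoxicity (on this read-out higher numbers stand for weaker inhibition and lower numbers for stronger inhibition), three compounds have been measured so far: compound 1 `COC(=O)C[C@@H]1NC(=O)[C@@H](C)NC(=O)[C@@H]2Cc3ccc(OC)c(c3)Oc3ccc(cc3)C[C@@H](C(=O)N2C)N(C)C(=O)[C@H](C)NC(=O)[C@H](Cc2ccc(OC)cc2)N(C)C1=O` gives 41.7 nM, compound 2 `COc1ccc(C[C@H]2C(=O)N[C@@H](C)C(=O)N(C)[C@H]3Cc4ccc(cc4)Oc4cc(ccc4OC)C[C@@H](C(=O)N[C@H](C)C(=O)N[C@@H](CC(=O)O)C(=O)N2C)N(C)C3=O)cc1` gives 1200 nM, and compound 3 `COc1ccc(C[C@H]2C(=S)N[C@@H](C)C(=O)N(C)[C@H]3Cc4ccc(cc4)Oc4cc(ccc4OC)C[C@@H](C(=O)N[C@H](C)C(=O)N[C@@H](C)C(=O)N2C)N(C)C3=O)cc1` gives 0.741 nM.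

Compound 2 differs from compound 1 in a single place, namely (hydrogen in place of methyl on an oxygen next to a carbonyl group). That change is tied to a large shift: a 29-fold higher number from compound 1 to compound 2 (1.46 log units; beyond the scatter). Compound 3 has the lowest number of the three, and the difference between the core of compound 3 and the core of compound 1 is not broken down here.

Compound 4 `COc1ccc(C[C@H]2C(=S)N[C@@H](C)C(=O)N(C)[C@H]3Cc4ccc(cc4)Oc4cc(ccc4O)C[C@@H](C(=O)N[C@H](C)C(=O)N[C@@H](C)C(=O)N2C)N(C)C3=O)cc1` has not yet been measured. It differs from compound 3 in one place: hydrogen in place of methyl on an oxygen on an aromatic ring. Among the compounds with values here, this is the same kind of change as the one from compound 1 to compound 2, since in both a methyl leaves an oxygen and a hydrogen enters, but it is not the same change. In the first case the oxygen sits next to a carbonyl group and its other neighbour is a carbonyl carbon; in the second the oxygen sits on an aromatic ring and its other neighbour is an aromatic carbon. The earlier step therefore serves only as a rough guide. A smaller step than a 29-fold higher number from compound 1 to compound 2 (1.46 log units; beyond the scatter) is expected for compound 4, namely a 2.7-fold higher number from compound 3 to compound 4 (0.43 log units; beyond the scatter). For compound 4 a value of about 2 nM is estimated, most likely between 0.5 nM and 10 nM.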

Compound 4, half-maximal inhibitory concentration: 1.15 nM
The estimate for compound 4 lay 1.7-fold (0.24 log units) above the measured number; low and high end bracket the measured number.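

In this assay, putting hydrogen in place of methyl on an oxygen on an aromatic ring gives a 1.6-fold higher number from compound 3 to compound 4 (0.19 log units; within the scatter), so on the core of compound 3 this methoxy to hydroxy swap leaves the read-out within the usual scatter of repeat measurements. Set beside the earlier swap, on an oxygen next to a carbonyl group, this shows that the size of the step does not carry over from one core to the other in this series: the same change on two cores in this assay, a 29-fold higher number (1.46 log units; beyond the scatter) from compound 1 to compound 2 and a 1.6-fold higher number (0.19 log units; within the scatter) from compound 3 to compound 4, 19-fold (1.27 log units) apart, beyond the scatter of two such steps. Within the data shown here, it does not show which difference matters, the core or the place of the oxygen, as the two steps differ in both, and one pair on each side gives no rule for other compounds.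

The compounds shown leave open what happens when the oxygen on the aromatic ring carries something other than methyl or hydrogen, such as an ethyl group or a longer chain, or when an amine stands in place of the hydroxy. They also leave open how the methoxy to hydroxy swap on an aromatic ring would read on the core of compound 1, which would test the core and the place of the oxygen separately.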